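Amino for chloro on the shared fused core

The source may hold more compounds than are shown below. What is called first, only, known or untested is meant among the compounds shown, and "the series" means these compounds.

Compound 2 `ClCc1cccc(Cn2cnc3c(Cl)nc(Cl)nc32)c1` gives 2340 nM in a functional assay on SK-MEL-28 cells (Homo sapiens) for cytotoxicity, read by sulforhodamine B assay, with a stated time of 48 h (on this read-out lower numbers stand for stronger inhibition of growth and higher numbers for weaker inhibition of growth), and compound 3 `ClCc1ccc(Cn2cnc3c(Cl)nc(Cl)nc32)cc1` gives 2690 nM; the two values lie within the scatter of each other, and the difference between the two cores is not broken down here. Compound 1 `Nc1nc(Cl)c2ncn(Cc3ccc(CCl)cc3)c2n1` gives 18200 nM. The change from compound 3 to compound 1 is amino in place of chloro on an aromatic carbon, and it made a 6.8-fold higher number from compound 3 to compound 1 (0.83 log units; beyond the scatter). Compound 4 `Nc1nc(Cl)c2ncn(Cc3cccc(CCl)c3)c2n1` is not yet measured; the change from compound 2 to compound 4 is amino in place of chloro on an aromatic carbon, the same change at the same place. A step of about the same size is expected from compound 2 to compound 4, a 6.4-fold higher number from compound 2 to compound 4 (0.81 log units; beyond the scatter). This expectation rests on compound 3 and compound 1, whose step is a 6.8-fold higher number from compound 3 to compound 1 (0.83 log units; beyond the scatter), and on compound 2, whose value is 2340 nM. For compound 4 the expected number in this assay is 15000 nM, with a range from 6000 nM to 40000 nM.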

Compound 4, concentration for 50% growth inhibition: 4460 nM
Estimate against measurement, compound 4: 3.4-fold (0.53 log units) above, outside the stated range (below it).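

In this assay amino in place of chloro on an aromatic carbon gives a 1.9-fold higher number from compound 2 to compound 4 (0.28 log units; within the scatter) and so its size does not carry from one core to the other: the same change on two cores in this assay, a 6.8-fold higher number (0.83 log units; beyond the scatter) from compound 3 to compound 1 and a 1.9-fold higher number (0.28 log units; within the scatter) from compound 2 to compound 4, 3.5-fold (0.55 log units) apart, beyond the scatter of two such steps.

The change cannot be treated as a fixed increment in this series. Among the compounds shown here, two cores show only that the steps differ, not why they differ or what size to expect on a third core.

Open, going by these compounds, is whether a methylamine or a methoxy group on the same aromatic carbon would follow either step. Also open, on these data alone, is whether a hydroxymethyl or a bromomethyl group in place of the chloromethyl group would alter the gap between the two steps.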